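Compound 3: sec-butyl replaces 2-cyclopropylethyl

This account rests on a few compounds, and the source may have more. Where it says the series, first, only, none or still open, it means among the compounds named here.

Compound 2 (`CS(=O)(=O)Nc1ccc2c(c1)S(=O)(=O)N=C(c1c(O)c(-c3cccs3)nn(CCC3CC3)c1=O)N2`) reads > 1 h in an in vitro ADME assay on microsomes from liver (Homo sapiens) for metabolic stability, tested at 5 uM (a lower number here means that the compound disappears faster, a higher number that the compound lasts longer), and that figure is a limit of the assay, not a number. Compound 2 is placed only by the limit of > 1 h in this assay, at which 1 of the 2 values shown sits, and has no exact figure of its own. Compound 1 (`CS(=O)(=O)Nc1ccc2c(c1)S(=O)(=O)N=C(c1c(O)c(-c3ccsc3)nn(CCC3CC3)c1=O)N2`), with thiophen-3-yl in place of thiophen-2-yl, gives 0.517 h in this assay as a true reading. Within the data shown here, the only measured step is an at least 1.9-fold higher number from compound 1 to compound 2 (0.28 log units; that floor lies within the scatter) and it changes the thiophene group, not the chain on the nitrogen.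

Compound 3 (`CCC(C)n1nc(-c2cccs2)c(O)c(C2=NS(=O)(=O)c3cc(NS(C)(=O)=O)ccc3N2)c1=O`) keeps the thiophen-2-yl group and carries sec-butyl in place of 2-cyclopropylethyl on an aromatic nitrogen. Among the measured compounds shown here, no measured step bears on this place, and no shift beyond the scatter is expected. The estimated move is a step that the limit leaves unreadable from compound 2 to compound 3 in this assay for this swap, with its direction left open. The expected half-life of compound 3 is 1.2 h with an estimated range from 0.5 h to 3 h on this reasoning.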

Compound 3, half-life: > 1 h
Compound 3 gave a limit, no number; the forecaster's own chance of this, stated with the estimate: 45%; the middle value lies beyond the limit too.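

Compound 2 and compound 3 both stand at a limit of this assay, not at a number, so the step between them cannot be read: the limit of > 1 h in this assay, at which 2 of the 3 values shown sit.

The compounds shown leave open how far beyond that limit either compound lies, and whether sec-butyl or 2-cyclopropylethyl on the aromatic nitrogen gives the longer half-life.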